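A few compounds are considered here, and "the series" means these few. Any claim that something is new, unique, unknown or untested is made for them only; others in the source may bear on it.

Measured compounds:
compound 1, `CCOC(=O)C1=C(C)NC(=S)NC1c1ccc(O)cc1`, 27.5 ug/mL
compound 2, `CCCc1ccc(C2NC(=S)NC(C)=C2C(=O)OCC)cc1`, 27.7 ug/mL
compound 3, `CCCc1ccc(C2NC(=O)NC(C)=C2C(=O)OCC)cc1`, 18.8 ug/mL

These three were tested in a functional assay on 786-0 cells (Homo sapiens) for inhibition, read by sulforhodamine B assay, with a stated time of 48 h; a higher number here means a weaker inhibitor of growth, a lower number a stronger inhibitor of growth. Compound 1 and compound 2 share one core, and compound 3 sits on a different core; how the two cores differ is not broken down here. Compound 1 and compound 2 differ in one place, (hydroxy in place of propyl on an aromatic carbon), and that change made a step of a 1.0-fold lower number from compound 2 to compound 1 (0.00 log units; within the scatter). Compound 4, `CCOC(=O)C1=C(C)NC(=O)NC1c1ccc(O)cc1`, has not yet been measured; it comes from compound 3 by hydroxy in place of propyl on an aromatic carbon, the same change. Since that change left the number flat between compound 2 and compound 1, the expectation for compound 4 in this assay is a step of about a 1.0-fold higher number from compound 3 to compound 4 (0.00 log units; within the scatter), resting on that single earlier pair. The estimate for compound 4 is therefore 19 ug/mL, expected to lie between 10 ug/mL and 36 ug/mL.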

Compound 4, concentration for 50% growth inhibition: 25.8 ug/mL
Estimate against measurement, compound 4: 1.4-fold (0.13 log units) below; measured number inside the range.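

In this assay putting hydroxy in place of propyl on the aromatic carbon gave a 1.4-fold higher number from compound 3 to compound 4 (0.14 log units; within the scatter) on the core of compound 3. Set beside the earlier pair, the change looks the same on both cores: the same change on two cores in this assay, a 1.0-fold lower number (0.00 log units; within the scatter) from compound 2 to compound 1 and a 1.4-fold higher number (0.14 log units; within the scatter) from compound 3 to compound 4, 1.4-fold (0.14 log units) apart, within the scatter of two such steps This shows that on these two cores the change made no step beyond the usual scatter, but with only two pairs in one assay it does not show that the same would hold on any other core, nor why the number responds so little.

The compounds shown leave open whether another group on that aromatic carbon, such as an amine, a carboxylic acid or a longer chain, would give a step beyond the scatter. They also leave open whether the change behaves alike in other cells.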